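Replacing the Amide Link With a Nitrogen-Bearing Link

The compounds below may be only part of what the source reports. "The series", "measured", "known", "first", "only" and "open" are said of these compounds alone.

compound 1 `COc1cc(-c2nn(-c3cccc(NC(=O)c4cccc(C(F)(F)F)c4)c3)cc2-c2ccncc2)ccc1Cl`: 1620 nM
compound 2 `COc1cc(-c2nn(-c3cccc(NC(=O)c4ccc(Cl)c(C(F)(F)F)c4)c3)cc2-c2ccncc2)ccc1Cl`: 3100 nM

Both compounds were tested in a functional assay on U-251 cells (Homo sapiens) for inhibition, read by sulforhodamine B assay, with a stated time of 48 h; on this read-out higher numbers stand for weaker inhibition of growth and lower numbers for stronger inhibition of growth. Compound 2 holds the higher of the two numbers, yet the step from compound 1 to it lies within the scatter: a 1.9-fold higher number from compound 1 to compound 2 (0.28 log units; within the scatter). So far, nothing separates the two compounds with confidence.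

Compound 3 `COc1cc(-c2nn(-c3cccc(NC(=O)Nc4ccc(Cl)c(C(F)(F)F)c4)c3)cc2-c2ccncc2)ccc1Cl` changes the carbonyl side of compound 2: (4-chloro-3-(trifluoromethyl)phenyl)amino in place of 4-chloro-3-(trifluoromethyl)phenyl on a carbonyl carbon. Going by the values given here, the only measured step involves a chloro added to an aromatic carbon and does not touch the carbonyl, so it offers no guide to this change. Among the compounds with values here, with no precedent, the expectation is a number close to that of compound 2, carrying a wide range. For compound 3 the expected step is a 1.2-fold lower number from compound 2 to compound 3 (0.09 log units; within the scatter), within the scatter. Compound 3 is therefore estimated at 2500 nM, with a plausible range from 700 nM to 9000 nM.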

Compound 3, concentration for 50% growth inhibition: 985 nM
The estimate for compound 3 lay 2.5-fold (0.40 log units) above the measured number; the range from low to high includes it.
By their numbers in this assay, from the lowest: compounds 3, 1 and 2 (each within the scatter of the next, the first and the last beyond it).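

In this assay, going by these compounds alone, the swap on the carbonyl carbon, (4-chloro-3-(trifluoromethyl)phenyl)amino in place of 4-chloro-3-(trifluoromethyl)phenyl, gives a 3.1-fold lower number from compound 2 to compound 3 (0.50 log units; beyond the scatter) and is the first step in this set to stand clear of the usual noise, showing that this position can shift growth inhibition, if only modestly. Set against compound 1, the step is a 1.6-fold lower number from compound 1 to compound 3 (0.22 log units; within the scatter) and stays inside that noise, so the gain is firm only against compound 2. No measurement here accounts for the change.

Going by these compounds, whether the gain depends on the added nitrogen itself stays open; a methylene or an oxygen on the carbonyl carbon, or a methylated nitrogen, would test that. Also open, on these data alone, is how 3-(trifluoromethyl)phenylamino, without the chloro, would behave on the same carbonyl carbon.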